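Pyridyl for dichlorophenyl on the ether side chain of compound 3

A few compounds are considered here, and "the series" means these few. Any claim that something is new, unique, unknown or untested is made for them only; others in the source may bear on it.

compound 1 `Cc1cc(C(=O)O)ccc1C(C)N1CCC[C@H](O[C@H](CO)c2cc(Cl)cc(Cl)c2)[C@@H]1c1ccccc1`: "nd" (no result reported)
compound 2 `OC[C@@H](O[C@H]1CCCN(Cc2ncc[nH]2)[C@H]1c1ccccc1)c1cc(Cl)cc(Cl)c1`: > 200000 nM
compound 3 `Cc1cc(C(=O)O)ccc1CN1CCC[C@H](OC(c2cc(Cl)cc(Cl)c2)C(C)O)[C@@H]1c1ccccc1`: > 196000 nM

Three compounds of the series share the same core and differ in the group on the ring nitrogen and in the ether-linked side chain. In an assay on isolated protein for activation of cGMP-dependent protein kinase 1 (Homo sapiens), read by ADP-Glo, with stated times of 30 min and 2 h (a lower number here means that less compound is needed, a higher number that more compound is needed for the effect), compound 1 is recorded as "nd" (no result reported), so no number exists for it. For compound 2 the result is only a limit of the assay, > 200000 nM. For compound 3 the result is likewise a limit of the assay, > 196000 nM. Compound 3 thus stands at a limit (the limit of > 196000 nM in this assay, at which 1 of the 3 values shown sits), with one further limit beside it (the limit of > 200000 nM in this assay, at which 1 of the 3 values shown sits) and one entry without a single number; no measured number exists anywhere in the series.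

Compound 4 `Cc1cc(C(=O)O)ccc1CN1CCC[C@H](O[C@H](CO)c2cc(Cl)nc(Cl)c2)[C@@H]1c1ccccc1` has not been measured. It differs from compound 3 in one place: a group of 11 heavy atoms (7 carbon, 1 nitrogen, 1 oxygen, 2 chlorine; one six-membered aromatic ring with 1 hetero atom) in place of a group of 12 heavy atoms (9 carbon, 1 oxygen, 2 chlorine; one six-membered aromatic ring of carbon only), on an oxygen on a saturated carbon. For the measured compounds named here, no step between measured compounds is available, so the size of this step in this assay cannot be read from the data; with both known results sitting at limits, no step beyond the scatter is expected in either direction. Compound 4 is therefore expected to give 200000 nM in this assay, within 60000 nM to 400000 nM, most likely again reported as a limit. This corresponds to an expected step that the limit leaves unreadable from compound 3 to compound 4.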

Compound 4, half-maximal effective concentration: > 200000 nM
Compound 4 ended at the assay's limit; the forecaster's own chance of this, stated with the estimate: 75%; the middle value sits exactly at the limit.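

For the compounds shown here, no step from compound 3 to compound 4 can be read in this assay: both results are limits of the assay, not numbers. The compounds shown leave open at what concentration either compound reaches the half-maximal effect, and whether the aromatic ring with 1 hetero atom, in place of the carbon-only ring, shifts that concentration in either direction.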